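Small Steps Among Three Compounds, and a Fluoro Analogue

The source may hold more compounds than are shown below. What is called first, only, known or untested is meant among the compounds shown, and "the series" means these compounds.

- Compound 1 `O=C(/C=C/c1cccc(Br)c1)NNC(=O)c1ccc2c(c1)OCCO2`: 351000 nM
- Compound 2 `O=C(/C=C/c1ccccc1)NNC(=O)c1ccc2c(c1)OCCO2`: 312000 nM
- Compound 3 `Cc1ccccc1/C=C/C(=O)NNC(=O)c1ccc2c(c1)OCCO2`: 268000 nM

In an ADME assay on cells (Macrophage) for cytotoxicity, read by MTT assay, with a stated time of 24 h (a higher number here means that more compound is tolerated, a lower number that less compound is tolerated), compound 3 gives 268000 nM and stands within the scatter of the other two compounds, with a 1.2-fold lower number from compound 2 to compound 3 (0.07 log units; within the scatter) and a 1.3-fold lower number from compound 1 to compound 3 (0.12 log units; within the scatter). Compound 4 `O=C(/C=C/c1cccc(F)c1)NNC(=O)c1ccc2c(c1)OCCO2`, not yet measured, differs from compound 3 as follows: 3-fluorophenyl in place of 2-methylphenyl on a double-bonded chain carbon bound to a double-bonded chain carbon. That is 3-fluorophenyl in place of 2-methylphenyl on a double-bonded chain carbon bound to a double-bonded chain carbon. For the measured compounds named here, no compound carrying fluorine has a measured value. The nearest evidence is the other exchanges on the aromatic ring, a 1.1-fold lower number from compound 1 to compound 2 (0.05 log units; within the scatter) and a 1.3-fold lower number from compound 1 to compound 3 (0.12 log units; within the scatter), so no step beyond the scatter is expected in this assay. The expected step is a 1.2-fold higher number from compound 3 to compound 4 (0.06 log units; within the scatter). Compound 4 is estimated at 310000 nM, with an expected range from 220000 nM to 430000 nM.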

Compound 4, half-maximal cytotoxic concentration: 221000 nM
Compound 4: the middle estimate sits 1.4-fold (0.15 log units) above what was measured; low and high end bracket the measured number.
By their numbers in this assay, from the lowest: compounds 4, 3, 2 and 1 (each within the scatter of the next).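

In this assay, fluoro joins bromo and hydrogen on the aromatic carbon, and neither fluoro in place of hydrogen (a 1.4-fold lower number from compound 2 to compound 4 (0.15 log units; within the scatter)) nor fluoro in place of bromo (a 1.6-fold lower number from compound 1 to compound 4 (0.20 log units; within the scatter)) leaves the scatter. The exchange of 2-methylphenyl for 3-fluorophenyl (a 1.2-fold lower number from compound 3 to compound 4 (0.08 log units; within the scatter)) also stays within it, so all four compounds now lie within the scatter of the next in line. No evidence is available that bears on these small steps.

Going by these compounds, whether an amine or a carboxylic acid on the aromatic ring would give a step beyond the scatter remains open.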